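Adding a Second Trifluoromethyl Group to Compound 1

The compounds below may be only part of what the source reports. "The series", "measured", "known", "first", "only" and "open" are said of these compounds alone.

Compound 1 `O=C(Nc1cccc(-n2cc(-c3ccncc3)c(-c3ccc(Cl)c(O)c3)n2)c1)Nc1cccc(C(F)(F)F)c1` was tested in a functional assay on DU-145 cells (Homo sapiens) for inhibition, read by sulforhodamine B assay, with a stated time of 48 h; a higher number here means that more compound is tolerated, a lower number that less compound is tolerated. In this assay compound 1 gives > 32500 nM, which is a limit of the assay and not a number. Compound 2 `O=C(Nc1cccc(-n2cc(-c3ccncc3)c(-c3ccc(Cl)c(O)c3)n2)c1)Nc1ccc(Cl)c(Cl)c1` gives > 32500 nM in this assay, again only a limit. The step from compound 1 to compound 2 is therefore unreadable: a step that the two limits leave unreadable from compound 1 to compound 2. Compound 3 `O=C(Nc1cccc(-n2cc(-c3ccncc3)c(-c3ccc(Cl)c(O)c3)n2)c1)Nc1cc(C(F)(F)F)cc(C(F)(F)F)c1` differs from compound 1 by trifluoromethyl in place of hydrogen on an aromatic carbon. Among the compounds with values here, since both measured values sit at the limit of > 32500 nM in this assay, at which 2 of the 2 values shown sit, no measured step bears on this change and no direction can be read from it. Compound 3 is expected to give 40000 nM (range 15000 nM to 100000 nM), an expected step that the limit leaves unreadable from compound 1 to compound 3 that would stay within the scatter.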

Compound 3, concentration lethal to 50% of the cells: 17400 nM
Beside the measured number, compound 3's estimate is 2.3-fold (0.36 log units) above it, and the stated range covers the measured number.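

Within the data shown here, with a second trifluoromethyl on an aromatic carbon, meta to a trifluoromethyl group, this assay gives a number rather than a limit for the first time, with an at least 1.8-fold lower number from compound 1 to compound 3 (0.27 log units; that floor lies within the scatter) as the step. That step is only a floor, so the change is not shown to go beyond the scatter. The other two compounds remain at the limit: the limit of > 32500 nM in this assay, at which 2 of the 3 values shown sit.

On these data alone, whether a methoxy, a nitrile or an amine at this place would also give a number remains open.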